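Compound 3 to Compound 4: Swapping the Aryl Group

The source may report more compounds than this note shows. Statements on the series, on what has been measured and on what is new or still open speak of the compounds shown alone.

Compound 1 `CCC(CC)C(N)CCN(C(=O)[C@@H]1C[C@H]1c1ccccc1)c1ccc(-c2ccccc2)cc1`: 2 nM
Compound 2 `O=C([C@@H]1C[C@H]1c1ccccc1)N(CCNCC1CCCCC1)c1ccc(-c2ccccc2)cc1`: 6.6 nM
Compound 3 `CC[C@H](C)[C@H](N)CN(C(=O)[C@@H]1C[C@H]1c1cccc(OC)c1)c1ccc(-c2ccccc2)cc1`: 3000 nM

In a functional assay for agonist activity at G protein-coupled receptor 88 (Homo sapiens), read by HTRF and cAMP accumulation (on this read-out higher numbers stand for an effect only at larger amounts of compound and lower numbers for an effect already at smaller amounts), compound 3 gives 3000 nM, the highest of the three numbers; compound 1 and compound 2 both lie far lower, beyond the scatter. Compound 4 `CC[C@H](C)[C@H](N)CN(C(=O)[C@@H]1C[C@H]1c1nc(C)c(C)s1)c1ccc(-c2ccccc2)cc1` differs from compound 3 in one place: 4,5-dimethyl-1,3-thiazol-2-yl in place of 3-methoxyphenyl on a saturated ring carbon. Within the data shown here, no measured step covers such a swap on the three-membered ring. Among the measured compounds shown here, the only measured step, a 3.3-fold higher number from compound 1 to compound 2 (0.52 log units; beyond the scatter), concerns the amine-bearing chain, and compound 1 and compound 2 differ from compound 3 in more than one place, so their values give no direct guide. For compound 4 a change within the scatter is therefore expected, no change at the digits printed from compound 3 to compound 4 (within the scatter), with a wide range. Compound 4 is estimated at 3000 nM, between 600 nM and 15000 nM.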

Compound 4, half-maximal effective concentration: 3600 nM
Compound 4: the middle estimate sits 1.2-fold (0.08 log units) below what was measured, within the range that was stated.
By their numbers in this assay, from the lowest: compound 1; then compound 2; then compounds 3 and 4 (each within the scatter of the next).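

In this assay, putting 4,5-dimethyl-1,3-thiazol-2-yl in place of 3-methoxyphenyl on the three-membered ring gives a 1.2-fold higher number from compound 3 to compound 4 (0.08 log units; within the scatter). At this position, then, a five-membered aromatic ring with two hetero atoms and a six-membered aromatic ring of carbon only give matching read-outs, despite their different ring types. No available evidence explains this match.

Among these compounds, this is only one pair of compounds, so it remains open whether a pyridin-2-yl group, or a thiazol-2-yl ring without its two methyl groups, would also match.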